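A few compounds are considered here, and "the series" means these few. Any claim that something is new, unique, unknown or untested is made for them only; others in the source may bear on it.

Of the compounds shown here, two built on a shared core have been measured so far. Compound 1 `COc1cc(/C=C/c2nc3cccnc3n(CC(=O)O)c2=O)ccc1O` gives 85.5% in a functional assay, read by spectrophotometry, with a stated time of 30 min, tested at 100 uM; on this read-out lower numbers stand for a weaker effect and higher numbers for a stronger effect at the one concentration tested. Compound 2 `O=C(O)Cn1c(=O)c(/C=C/c2ccc(O)c(O)c2)nc2cc(Cl)cnc21` gives 97.1% in this assay, the higher of the two numbers, and its gap to compound 1 lies beyond the usual scatter. Compound 3 `COc1cc(/C=C/c2nc3cc(Cl)cnc3n(CC(=O)O)c2=O)ccc1O` differs from compound 2 by methyl in place of hydrogen on an oxygen on an aromatic ring. Among the compounds with values here, no measured pair differing in that single place exists to show the size of such a step. Compound 3 is expected to sit slightly lower, a step of a number 9.1 percentage points lower from compound 2 to compound 3 (within the scatter) that stays within the scatter. Compound 3 is estimated at 88%, within 75% to 98%.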

Compound 3, a percentage reported as activity, at one concentration (the size of the read-out at that concentration, not a potency): 94.9%
For compound 3 the middle estimate is 6.9 percentage points below the measured one; low and high end bracket the measured number.
By their numbers in this assay, from the lowest: compounds 1, 3 and 2 (each within the scatter of the next, the first and the last beyond it).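

In this assay, the change from hydroxy to methoxy on the aromatic ring gives a number 2.2 percentage points lower from compound 2 to compound 3 (within the scatter) and so shows that, with the chloro present, methyl in place of hydrogen on this oxygen leaves the number within the scatter. Chloro in place of hydrogen on an aromatic carbon gives a number 9.4 percentage points higher from compound 1 to compound 3 (within the scatter) and is likewise within the scatter. The data hold no evidence that bears on either step. Still open, on these data alone, is whether an ethyl or a longer chain on this oxygen would leave the number within the scatter, and whether a bromo or a methyl in place of the chloro would do the same.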